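The source may report more compounds than this note shows. Statements on the series, on what has been measured and on what is new or still open speak of the compounds shown alone.

Compound 3 `Cc1ccc(OCC(=O)N(Cc2cccs2)C(C)(C)C)cc1` gives 11000 nM in an assay on HEK293 cells for agonist activity at transient receptor potential cation channel subfamily M member 8 (Homo sapiens), read by fluorescence and calcium flux, with a stated time of 15 min (on this read-out higher numbers stand for an effect only at larger amounts of compound and lower numbers for an effect already at smaller amounts), the highest of the three numbers measured. Compound 2 `CCC(C)N(Cc1cccs1)C(=O)COc1ccc(C)cc1` gives 2000 nM in this assay, and compound 1 `CCN(Cc1cccs1)C(=O)COc1ccc(F)cc1` gives 422 nM. Among the measured compounds shown here, the one measured single change is a 5.5-fold higher number from compound 2 to compound 3 (0.74 log units; beyond the scatter). Compound 4 `Cc1ccc(OCC(=O)N(CCO)Cc2cccs2)cc1` differs from compound 3 by 2-hydroxyethyl in place of tert-butyl on an amide-type nitrogen. The measured step bears on this: compound 3 with tert-butyl stands above compound 2 with sec-butyl, and compound 1 with ethyl gives the lowest number, although compound 1 also differs from the others elsewhere in the shared core. A change away from tert-butyl is therefore expected to lower the number in this assay, by about a 4.4-fold lower number from compound 3 to compound 4 (0.64 log units; beyond the scatter). Compound 4 is estimated at 2500 nM, expected between 600 nM and 10000 nM.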

Compound 4, half-maximal effective concentration: 900 nM
Estimate against measurement, compound 4: 2.8-fold (0.44 log units) above; the range from low to high includes it.
By their numbers in this assay, from the lowest: compound 1; then compound 4; then compound 2; then compound 3.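

Until now this position held only alkyl groups. With 2-hydroxyethyl on the amide-type nitrogen, this assay shows a 12-fold lower number from compound 3 to compound 4 (1.09 log units; beyond the scatter) and also a 2.2-fold lower number from compound 2 to compound 4 (0.35 log units; beyond the scatter), so a chain ending in a hydroxyl group is accepted here and gives a lower number than either branched alkyl group. Nothing shown accounts for these steps.

Going by these compounds, whether the hydroxyl group or the unbranched chain matters stays open, as compound 1 carries ethyl but also differs elsewhere in the shared core. On these data alone, how an amine, a carboxylic acid or a longer chain would read at this position also stays open.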